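Trimming the four-membered ring: what solubility to expect

A few compounds are considered here, and "the series" means these few. Any claim that something is new, unique, unknown or untested is made for them only; others in the source may bear on it.

Of the compounds shown here, three sharing one core have been tested in a physicochemical assay for solubility, at pH 7.4; on this read-out lower numbers stand for lower solubility and higher numbers for higher solubility. Compound 2 `C[C@H]1N(c2cc3c(cc2F)c(=O)c(C(=O)O)cn3C2CC2)C[C@]1(C)N` stands second highest of the three: in this assay compound 2 gives 1.3 ug/mL. Its nearest neighbour is compound 3 `CNC1(C)CN(c2c(F)cc3c(=O)c(C(=O)O)cn(C4CC4)c3c2F)C1`, which in this assay gives 0.5 ug/mL, a gap beyond the usual scatter. Furthest away is compound 1 `C[C@H]1[C@H](N)CN1c1c(F)cc2c(=O)c(C(=O)O)cn(C3CC3)c2c1Cl`, which in this assay gives 12 ug/mL, again clearly beyond the scatter.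

Compound 4 `C[C@H]1[C@@H](N)CN1c1cc2c(cc1F)c(=O)c(C(=O)O)cn2C1CC1` has not yet been measured. Compared with compound 2 it carries a change on an aromatic carbon: a group of 6 heavy atoms (4 carbon, 2 nitrogen; one four-membered non-aromatic ring with 1 hetero atom) in place of a group of 7 heavy atoms (5 carbon, 2 nitrogen; one four-membered non-aromatic ring with 1 hetero atom), on an aromatic carbon The ring that enters is the smaller of the two, and the count of hydrogen-bond donors and acceptors stays the same.

Within the data shown here, no measured pair shows exactly this change, so the expectation rests on the loss of one carbon alone. A small rise in this assay is expected, of about a 2.3-fold higher number from compound 2 to compound 4 (0.36 log units; beyond the scatter), close to the edge of the scatter. For compound 4 the estimated value in this assay is 3 ug/mL, with a likely range from 1 ug/mL to 10 ug/mL.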

Compound 4, solubility: 6.1 ug/mL
Compound 4: middle estimate off by 2.0-fold (0.31 log units), on the low side, and the stated range covers the measured number.
By their numbers in this assay, from the lowest: compound 3; then compound 2; then compounds 4 and 1 (each within the scatter of the next).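

In this assay, among these compounds, compounds 2 and 4 give the first pair that differs in one place, so the effect of this change on an aromatic carbon can now be read directly. The group of 6 heavy atoms in place of the group of 7 heavy atoms gives a 4.7-fold higher number from compound 2 to compound 4 (0.67 log units; beyond the scatter), a modest step beyond the scatter, even though both groups hold one four-membered non-aromatic ring with 1 hetero atom and match in their counts of hydrogen-bond donors and acceptors. Nothing measured here accounts for the size of this step.

On these data alone, it remains open whether the same change would give a similar step on the core of compound 1 or compound 3. As far as these compounds go, it is also open how a larger ring at this aromatic carbon, such as a pyrrolidine or a piperazine, would compare with these four-membered rings.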